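Chloro in Place of Methoxy on Compound 3

The source may report more compounds than this note shows. Statements on the series, on what has been measured and on what is new or still open speak of the compounds shown alone.

Compound 1 (`Cc1ccc(S(=O)(=O)Oc2ccccc2/C=C(\C#N)C(=O)Nc2nnc(C)s2)cc1`) reaches only a limit in a functional assay on RS4-11 cells (Homo sapiens) for inhibition, read by CCK-8 assay, with a stated time of 48 h; a lower number here means a stronger inhibitor, a higher number a weaker inhibitor (> 20000 nM). Compound 2 (`COc1ccc(S(=O)(=O)Nc2cccc(/C=C(\C#N)C(=O)Nc3nnc(-c4cccs4)s3)c2)cc1`) likewise reaches only a limit (> 20000 nM). Compound 3 (`COc1ccc(Cc2nnc(NC(=O)/C(C#N)=C/c3ccccc3OS(=O)(=O)c3ccc(OC)cc3)s2)cc1`) alone gives an actual number (840 nM). Compound 4 (`COc1ccc(Cc2nnc(NC(=O)/C(C#N)=C/c3ccccc3OS(=O)(=O)c3ccc(Cl)cc3)s2)cc1`) carries chloro in place of methoxy on an aromatic carbon, para to a large group (chloro in place of methoxy on an aromatic carbon). Among the measured compounds shown here, no measured pair shows this change, so the expectation rests on compound 3 (840 nM) and is for no step beyond the scatter, in either direction, in this assay (a 1.1-fold lower number from compound 3 to compound 4 (0.05 log units; within the scatter) is the estimated step). For compound 4 the expected value is 750 nM with an estimated range from 280 nM to 2200 nM in that read-out.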

Compound 4, half-maximal inhibitory concentration: 4020 nM
For compound 4 the middle estimate is 5.4-fold (0.73 log units) below the measured one; the measured number lies above the stated range.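

Chloro in place of methoxy, para to a large group, gives a 4.8-fold higher number from compound 3 to compound 4 (0.68 log units; beyond the scatter) in this assay, the first step that can be read here, so this position is not indifferent to the change. Compound 4 still gives an actual number rather than a limit, so this change does not carry it to the limit of the assay: the limit of > 20000 nM in this assay, at which 2 of the 4 values shown sit.

Going by these compounds, whether the weaker result comes from the loss of methoxy or from the arrival of chloro stays open. On these data alone, how an ethoxy, a fluoro or an amine would read at this place also stays open.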